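This account rests on a few compounds, and the source may have more. Where it says the series, first, only, none or still open, it means among the compounds named here.

In a functional assay on PC-3 cells (Homo sapiens) for cytotoxicity, read by colorimetric assay and MTT assay (on this read-out lower numbers stand for stronger inhibition and higher numbers for weaker inhibition), compound 1 (`COc1cccc2cc(-c3ccccc3)c(O)nc12`) gives 10000 nM as its reading. Compound 2 (`CCOC(=O)Cn1c(=O)c(-c2ccc(OC)cc2)cc2c(OC)cc(OC)cc21`) gives 10000 nM in this assay as well, which places it level with compound 1, with no order between the two. For the measured compounds named here, these two compounds differ in more than one place, so their pair isolates no single change, and no measured step speaks to the next one. Compound 3 (`CCN(CC)C(=O)Cn1c(=O)c(-c2ccc(OC)cc2)cc2c(OC)cc(OC)cc21`) departs from compound 2 in one place: diethylamino in place of ethoxy on a carbonyl carbon with diethylamino in place of ethoxy on a carbonyl carbon, which reads as ethoxycarbonyl to diethylcarbamoyl. With compound 2 at 10000 nM as the only close reference, no shift beyond the usual scatter is expected in this assay for this change, and a modest move toward stronger inhibition is the likelier departure. The expected change is a 1.4-fold lower number from compound 2 to compound 3 (0.15 log units; within the scatter) and remains an estimate resting on very little data. The estimate for compound 3 is 7000 nM with an expected range from 2000 nM to 20000 nM in this read-out.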

Compound 3, half-maximal inhibitory concentration: 10000 nM
The estimate for compound 3 lay 1.4-fold (0.15 log units) below the measured number; the range from low to high includes it.
By their numbers in this assay, from the lowest: compounds 1, 2 and 3 (each within the scatter of the next).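

Putting diethylamino in place of ethoxy on a carbonyl carbon gives no change at the digits printed from compound 2 to compound 3 (within the scatter) in this assay. For the compounds shown here, this is the first step that isolates a single change, and it shows that going from (ethoxycarbonyl)methyl to (diethylcarbamoyl)methyl on this shared core leaves the reading where it was, with compound 3 at 10000 nM. No accompanying measurement bears on the reason for this result.

Still open, from the compounds shown here alone, is whether a carboxylic acid, a morpholine amide or a longer chain in this place would part from compound 2 in this assay. Going by these compounds alone, the series so far holds no step beyond the scatter, so it remains unknown whether any change at this place, or elsewhere on the shared core, such as removing a methoxy group, can move the reading at all.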